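This account rests on a few compounds, and the source may have more. Where it says the series, first, only, none or still open, it means among the compounds named here.

Compound 2 `COc1cc([C@H]2C[C@@]2(CO)C(=O)Nc2ccccc2)cc(OC)c1OC` and compound 1 `CCOC(=O)[C@@]1(C(=O)Nc2ccccc2)C[C@@H]1c1cc(OC)c(OC)c(OC)c1` share a core and differ in one place: ethoxycarbonyl in place of hydroxymethyl on a saturated ring carbon. Both were tested in a functional assay on SW480 cells (Homo sapiens) for cytotoxicity, read by MTT assay, with a stated time of 48 h; on this read-out higher numbers stand for weaker inhibition and lower numbers for stronger inhibition. In this assay compound 2 gives > 100000 nM, which is a limit of the assay rather than a number. Compound 1 likewise gives > 100000 nM, again a limit. The step from a step that the two limits leave unreadable from compound 2 to compound 1 cannot be read because of the limit of > 100000 nM in this assay, at which 2 of the 3 values shown sit. Among the compounds with values here, compound 3 `COc1cc([C@H]2C[C@]2(CO)C(=O)Nc2ccccc2Cl)cc(OC)c1OC` has a core whose difference from that of compound 2 is not broken down here; in this assay compound 3 gives 40200 nM, the only actual number among the three. Compound 4 `CCOC(=O)[C@]1(C(=O)Nc2ccccc2Cl)C[C@@H]1c1cc(OC)c(OC)c(OC)c1`, not yet measured, differs from compound 3 by ethoxycarbonyl in place of hydroxymethyl on a saturated ring carbon, the same change as between compound 2 and compound 1, at the same place. Resting on the value of compound 3, 40200 nM, and on the earlier unreadable step, compound 4 is expected to sit close by, a step of a 1.2-fold higher number from compound 3 to compound 4 (0.09 log units; within the scatter). Compound 4 is estimated at 50000 nM, between 15000 nM and 150000 nM.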

Compound 4, half-maximal inhibitory concentration: > 100000 nM
Compound 4: only a limit was reported; the forecaster's own chance of this, stated with the estimate: 40%; middle value at least 2.0-fold (0.30 log units) from the limit.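

In this assay, putting ethoxycarbonyl in place of hydroxymethyl on the core of compound 3 gives an at least 2.4-fold higher number from compound 3 to compound 4 (0.39 log units; beyond the scatter), so on this core the change clearly weakens inhibition. In this assay, as far as these compounds go, compound 4 gives > 100000 nM, which is a limit and not a number, so the true size of this step stays unknown. Whether the change acts the same way on both cores cannot be told, because the step from compound 2 to compound 1 cannot be read, with both ends at the limit: the limit of > 100000 nM in this assay, at which 3 of the 4 values shown sit.

From the compounds shown here alone, it remains open whether an amine or a carboxylic acid in place of hydroxymethyl on this saturated ring carbon would give stronger inhibition than compound 3 does. Going by these compounds, the effect of a longer chain at this place is also open.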